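The source may hold more compounds than are shown below. What is called first, only, known or untested is meant among the compounds shown, and "the series" means these compounds.

In an ADME assay on HepG2 2.2.15 cells (Homo sapiens) for cytotoxicity (on this read-out lower numbers stand for higher toxicity in this test and higher numbers for lower toxicity in this test), compound 1 (`CC12CCC(C(=O)OCCc3c(-c4ccccc4Cl)c4cc(Cl)ccc4[nH]c3=O)(OC1=O)C2(C)C`) gives > 1800000 nM, a limit and not a number. Compound 2 (`O=C(/C=C/c1ccc(C(F)(F)F)cc1)OCCc1c(-c2ccccc2Cl)c2cc(Cl)ccc2[nH]c1=O`) gives > 1400000 nM, and this too is only a limit, so its place on the scale has no exact number. Compound 3 (`COc1ccc(/C=C/C(=O)OCCc2c(-c3ccccc3Cl)c3cc(Cl)ccc3[nH]c2=O)cc1OC`) keeps the shared core and changes one group: 3,4-dimethoxyphenyl in place of 4-(trifluoromethyl)phenyl on a double-bonded chain carbon bound to a double-bonded chain carbon. Within the data shown here, the only measured step that bears on this is a step that the two limits leave unreadable from compound 1 to compound 2. That step altered a different stretch of the molecule and has no readable size, so it offers no size to carry over. Among the measured compounds shown here, with no sized step to go on, no change beyond the usual scatter is expected in this assay, and no direction can be favoured. The expected change is a step that the limit leaves unreadable from compound 2 to compound 3. Compound 3 is estimated at 1500000 nM, with an expected range from 500000 nM to 3000000 nM, and it will probably also be reported only as a limit.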

Compound 3, half-maximal cytotoxic concentration: > 1200000 nM
Compound 3: no number, only a limit (the forecaster's own chance of this, stated with the estimate: 85%); the middle value is on the limit's open side.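

Among these compounds, compound 1, compound 2 and compound 3 are each reported only as a limit in this assay, so no step among them can be read. The compounds shown leave open where each truly lies, and whether 3,4-dimethoxyphenyl and 4-(trifluoromethyl)phenyl differ at all on this read-out.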